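A few compounds are considered here, and "the series" means these few. Any claim that something is new, unique, unknown or untested is made for them only; others in the source may bear on it.

Compound 2, `CCC1CCCCC1OCCCCCCN1C[C@H](O)[C@@H](O)[C@H](O)[C@H]1CO`, was examined in an ADME assay on MDBK cells (Bos taurus) for cytotoxicity, read by MTT assay (on this read-out lower numbers stand for higher toxicity in this test and higher numbers for lower toxicity in this test), where compound 2 gives 450000 nM. Compound 1, `COc1ccc(OCCCCCCN2C[C@H](O)[C@@H](O)[C@H](O)[C@H]2CO)cc1`, reaches only a limit of the assay in this assay, > 500000 nM. The step of an at least 1.1-fold lower number from compound 1 to compound 2 (0.04 log units; that floor lies within the scatter) rests on the limit of > 500000 nM in this assay, at which 1 of the 2 values shown sits, and so is no more than a floor. Among the numbers shown, compound 2 holds the one value that is a number rather than a limit. Compound 3, `CC1CCC(OCCCCCCN2C[C@H](O)[C@@H](O)[C@H](O)[C@H]2CO)CC1C`, differs from compound 2 by a group of 8 heavy atoms (8 carbon; one six-membered non-aromatic ring of carbon only) in place of a group of 8 heavy atoms (8 carbon; one six-membered non-aromatic ring of carbon only), on an oxygen on a saturated carbon. Among the compounds with values here, the single measured step, an at least 1.1-fold lower number from compound 1 to compound 2 (0.04 log units; that floor lies within the scatter), concerns an aromatic group giving way to a non-aromatic one, and no measured step exchanges one saturated six-membered ring of carbon for another built of the same atoms. Nothing in the two values shown points in either direction. The expected step, no change at the digits printed from compound 2 to compound 3 (within the scatter), is therefore none beyond the scatter. Compound 3 is estimated at 450000 nM, with a range from 200000 nM to 1000000 nM, and the chance that this assay reports only a limit for compound 3 is sizable.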

Compound 3, half-maximal cytotoxic concentration: > 500000 nM
Compound 3 was reported as a limit; the forecaster's own chance of this, stated with the estimate: 40%; at least 1.1-fold (0.04 log units) between middle value and limit.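

Within the data shown here, for the first time, one saturated six-membered ring of carbon replaces another built of the same atoms, on an oxygen on a saturated carbon, and in this assay this exchange gives an at least 1.1-fold higher number from compound 2 to compound 3 (0.04 log units; that floor lies within the scatter). This step is only a floor and lies within the scatter, so it does not separate the two rings, and any true difference between them stays out of reach: the limit of > 500000 nM in this assay, at which 2 of the 3 values shown sit. The step between compound 1 and compound 3 cannot be read, as both values are limits.

The compounds shown leave open whether an amine or a carboxylic acid on the ring, or a chain longer than the one the compounds share, would move the result in this assay beyond the scatter. They also leave open whether a plain octyl chain on the same oxygen, with no ring at all, would give a number or a limit.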